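The source may report more compounds than this note shows. Statements on the series, on what has been measured and on what is new or still open speak of the compounds shown alone.

Measured so far:

Compound 1, `CN1[C@@H]2c3[nH]c4ccccc4c3C[C@H]1[C@H](C#N)N1[C@@H](CN3C(=O)c4ccccc4C3=O)c3[nH]c4ccccc4c3C[C@@H]21`: in a functional assay on A2780 cells (Homo sapiens) for cytotoxicity, read by MTT assay, with a stated time of 72 h (on this read-out higher numbers stand for weaker inhibition and lower numbers for stronger inhibition), compound 1 gives 80 nM.
Compound 2, `CN1[C@@H]2c3[nH]c4ccccc4c3C[C@H]1[C@H](C#N)N1[C@@H](CNC(=O)c3cccc(C(F)(F)F)c3)c3[nH]c4ccccc4c3C[C@@H]21`: in this assay compound 2 gives 210 nM.

Of these two numbers, compound 2 stands at the higher end, and the gap down to compound 1 lies beyond the usual scatter of the measurement. The two compounds differ in more than one place, so their values show only where each stands, not what any single change does.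

Compound 3, `CN1[C@@H]2c3[nH]c4ccccc4c3C[C@H]1[C@H](C#N)N1[C@@H](CNC(=O)c3ccc(Cl)cc3)c3[nH]c4ccccc4c3C[C@@H]21`, differs from compound 2 in a single place: 4-chlorophenyl in place of 3-(trifluoromethyl)phenyl on a carbonyl carbon. Both groups are plain six-membered aromatic rings that carry no hydrogen-bond donor or acceptor, and both sit on the same carbonyl carbon next to the amide-type nitrogen. Among the measured compounds shown here, no measured pair shows what such a swap does on this core, so there is no basis for expecting a shift in either direction.

For compound 3 the expected value in this assay is therefore close to that of compound 2, about 200 nM, with a range from 80 nM to 500 nM, which means an expected step of a 1.1-fold lower number from compound 2 to compound 3 (0.02 log units; within the scatter) that stays within the scatter.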

Compound 3, half-maximal inhibitory concentration: 230 nM
Compound 3: the middle estimate sits 1.2-fold (0.06 log units) below what was measured; measured number inside the range.
By their numbers in this assay, from the lowest: compound 1; then compounds 2 and 3 (each within the scatter of the next).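

In this assay, putting 4-chlorophenyl in place of 3-(trifluoromethyl)phenyl on a carbonyl carbon gives a step that stays within the scatter (a 1.1-fold higher number from compound 2 to compound 3 (0.04 log units; within the scatter)), so this position tolerates this particular swap of one aromatic ring for another, even though the two groups carry different substituents and differ in heavy-atom count. The step that lies beyond the scatter, though still modest, comes from changing the whole group on the saturated chain carbon bound to a saturated ring carbon: the group of compound 1, with its five-membered non-aromatic ring, gives way to the group of compound 3, with its single six-membered aromatic ring (a 2.9-fold higher number from compound 1 to compound 3 (0.46 log units; beyond the scatter)). Nothing measured on these compounds other than this read-out is available to explain either step.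

As far as these compounds go, what a plain alkyl chain, or a ring carrying an amine, would do in place of the aromatic ring on this carbonyl carbon stays open. Also open is what the nitrile contributes, since all the compounds shown carry it on the shared core, so no pair here tests its replacement by, for example, a carboxylic acid.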